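A fluorophenoxy analogue of a limited thioether

A few compounds are considered here, and "the series" means these few. Any claim that something is new, unique, unknown or untested is made for them only; others in the source may bear on it.

Compound 3 `COc1ccc(Sc2nc3cc(N)cc(N)c3nc2-c2ccccc2)cc1` is the point of departure. In a functional assay on U-251 cells (Homo sapiens) for inhibition, read by sulforhodamine B assay, with a stated time of 48 h (a lower number here means a stronger inhibitor of growth, a higher number a weaker inhibitor of growth), compound 3 gives < 100000 nM, which is a limit of the assay and not a number. Among the other measured compounds of the same shared core, compound 1 `Nc1cc(N)c2nc(-c3ccccc3)c(Oc3ccc(Cl)c(Cl)c3)nc2c1` gives 12000 nM in this assay, and compound 2 `Nc1cc(N)c2nc(-c3ccccc3)c(NCc3ccc(Cl)c(Cl)c3)nc2c1` gives 2090 nM. Within the data shown here, of the measured steps only one touches compound 3: the step from compound 1 to compound 3 is a step that the limit leaves unreadable from compound 1 to compound 3, because the limit of < 100000 nM in this assay, at which 1 of the 3 values shown sits, leaves its size unreadable. The step to the unmeasured compound 4 `Nc1cc(N)c2nc(-c3ccccc3)c(Oc3ccc(F)cc3)nc2c1` is 4-fluorophenoxy in place of (4-methoxyphenyl)sulfanyl on an aromatic carbon. It returns the linkage to an oxygen-bridged phenyl ring, as in compound 1, while the ring now carries a single fluorine in place of the two chlorines. Among the measured compounds shown here, compound 3 stands only at a limit, so no measured step gives the size of the change from it to compound 4. The nearest guide is compound 1 with 12000 nM, to which compound 4 is expected to be close, with some allowance for the lighter halogen pattern. Compound 4 is therefore expected to give about 20000 nM in this assay, within 5000 nM to 90000 nM. The step from compound 3 to compound 4 is accordingly estimated at a step that the limit leaves unreadable from compound 3 to compound 4, with the understanding that compound 3 itself is known only as a limit.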

Compound 4, concentration for 50% growth inhibition: 23400 nM
Compound 4: the middle estimate sits 1.2-fold (0.07 log units) below what was measured; low and high end bracket the measured number.
By their numbers in this assay, from the lowest: compound 2; then compounds 1 and 4 (each within the scatter of the next).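

With compound 4, the oxygen-linked series at this position, next to the ring nitrogen, has a second readable value in this assay. Exchanging 3,4-dichlorophenyl for 4-fluorophenyl on the oxygen gives a 2.0-fold higher number from compound 1 to compound 4 (0.29 log units; within the scatter), so among these two compounds the two chlorines and the single fluorine are not separated by this read-out. Both steps that touch compound 3 remain unreadable because compound 3 is known only as a limit of the assay and not as a number: the limit of < 100000 nM in this assay, at which 1 of the 4 values shown sits.

The compounds shown therefore leave open whether the sulfur link or the methoxy group sets compound 3 apart, a question that a phenoxy ring carrying methoxy or a phenylsulfanyl ring carrying fluorine could address. They also leave open how this position would respond to a phenoxy ring with no halogen at all, or to a basic group such as a morpholine or a piperidine in place of the aromatic ring.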